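The source may hold more compounds than are shown below. What is called first, only, known or untested is meant among the compounds shown, and "the series" means these compounds.

Measured compounds:
- compound 1, `COc1ccc(-n2c(SC)nnc2-c2cc(OC)c(OC)c(OC)c2)cc1`: in a functional assay on PC-3 cells (Homo sapiens) for inhibition, read by MTT assay, with a stated time of 48 h (on this read-out lower numbers stand for stronger inhibition and higher numbers for weaker inhibition), compound 1 reaches only the limit > 60000 nM, which is a boundary of the assay and not a number.
- compound 2, `COc1ccc(-n2c(SCc3ccccc3)nnc2-c2cc(OC)c(OC)c(OC)c2)cc1`: in this assay compound 2 gives 34100 nM.

Within the data shown here, compound 2 thus holds the only true number in this assay; the other value shown, (the limit of > 60000 nM in this assay, at which 1 of the 2 values shown sits), is a limit. Among the measured compounds shown here, the one measured step, an at least 1.7-fold lower number from compound 1 to compound 2 (0.24 log units; that floor lies within the scatter), sets a floor that still lies within the usual scatter, so it shows no change that can be trusted.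

Compound 3, `CCOC(=O)CSc1nnc(-c2cc(OC)c(OC)c(OC)c2)n1-c1ccc(OC)cc1`, differs from compound 2 in exactly this place: ethoxycarbonyl in place of phenyl on a saturated chain carbon bound to a sulfur. The step from compound 1 to compound 2 touched the same saturated chain carbon bound to a sulfur, but it brought no step beyond the scatter, and nothing measured tells how ethoxycarbonyl behaves there. The expectation for compound 3 is therefore a number near that of compound 2, with the step of a 1.2-fold higher number from compound 2 to compound 3 (0.07 log units; within the scatter) expected to stay within the scatter. Compound 3 is estimated at 40000 nM, within a range from 15000 nM to 90000 nM.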

Compound 3, half-maximal inhibitory concentration: > 60000 nM
Compound 3 ended at the assay's limit; the forecaster's own chance of this, stated with the estimate: 35%; middle value at least 1.5-fold (0.17 log units) away from the limit.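

The new result adds a second group on this carbon, and it differs sharply from phenyl in kind: ethoxycarbonyl has no ring and brings hydrogen-bond acceptors. Even so, this exchange gives an at least 1.7-fold higher number from compound 2 to compound 3 (0.24 log units; that floor lies within the scatter), so in this assay it shows no change that can be trusted, just as the step that introduced the phenyl showed none. The step from compound 1 to compound 3 cannot be read, and with compound 3 also ending at a limit, compound 2 remains the only compound here with a true number, so the series still offers no measured difference at this position: the limit of > 60000 nM in this assay, at which 2 of the 3 values shown sit.

As far as these compounds go, it remains open whether any group on this saturated chain carbon bound to a sulfur can produce a change beyond the usual scatter in this assay. Among these compounds, a carboxylic acid or an amine in place of the ethoxycarbonyl, or a longer chain carrying the phenyl, would test that question, and any of them that gave a true number would allow a first readable comparison with compound 2.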